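Series at the assay limit: hydroxymethyl for ethoxycarbonyl

The source may hold more compounds than are shown below. What is called first, only, known or untested is meant among the compounds shown, and "the series" means these compounds.

Measured in a functional assay on K562 cells (Homo sapiens) for cytotoxicity, read by MTT assay, with a stated time of 48 h; on this read-out lower numbers stand for stronger inhibition and higher numbers for weaker inhibition:
- compound 1 `COc1cc([C@@H]2C[C@@]2(CO)C(=O)Nc2ccccc2)cc(OC)c1OC`: > 100000 nM (limit)
- compound 2 `CCOC(=O)[C@@]1(C(=O)NCc2ccc(C)cc2)C[C@H]1c1cc(OC)c(OC)c(OC)c1`: > 100000 nM (limit)
- compound 3 `CCOC(=O)[C@]1(C(=O)NCc2ccc(C)cc2)C[C@H]1c1cc(OC)c(OC)c(OC)c1`: > 100000 nM (limit)

Compound 2 is known only as a limit, > 100000 nM, so it has no number to start from. All of the data rest on (the limit of > 100000 nM in this assay, at which 3 of the 3 values shown sit).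

Compound 4 `COc1cc([C@@H]2C[C@@]2(CO)C(=O)NCc2ccc(C)cc2)cc(OC)c1OC` follows from compound 2 by a single change: hydroxymethyl in place of ethoxycarbonyl on a saturated ring carbon. In words, this is hydroxymethyl in place of ethoxycarbonyl on a saturated ring carbon.

For the measured compounds named here, the only measured step is a step that the two limits leave unreadable from compound 2 to compound 3, and it rests on (the fact that compounds 2 and 3 differ only in the configuration as drawn). It gives no size for the present change. Compound 1 also carries hydroxymethyl, and it too is a limit, > 100000 nM. Going by the values given here, no measured compound in this assay gives a number, so no gain is expected on these data.

The expected step is a number no higher from compound 2 to compound 4 (the limit leaves the size open), with no size estimated beyond the scatter. For compound 4 the estimate is 100000 nM, with an expected range of 30000 nM to 200000 nM.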

Compound 4, half-maximal inhibitory concentration: > 100000 nM
Compound 4: only a limit was reported (the forecaster's own chance of this, stated with the estimate: 75%); the middle value sits exactly at the limit.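

In this assay compound 4 gives > 100000 nM, a limit and not a number. Neither step to compound 4, from compound 2 or from compound 1, can be read. The compounds shown leave open how large either change is, and whether any change to the shared core gives a measurable value in this assay.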